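The source may report more compounds than this note shows. Statements on the series, on what has been measured and on what is new or still open speak of the compounds shown alone.

Compound 1 `O=S(=O)(CC1=NCCS1)C1C(c2ccccc2)=NN(c2ccccc2)C1c1ccccc1` is described in a functional assay, read by Griess assay, with a stated time of 150 min, tested at 100 ug/mL (a lower number here means a weaker effect, a higher number a stronger effect of the compound at the concentration tested), as "not active" (no number reported), with no single number given. Compound 2 `COc1ccc(C2=NN(c3ccccc3)C(c3ccc(C)cc3)C2S(=O)(=O)CC2=NCCO2)cc1` gives 70.5% in this assay, and compound 3 `COc1ccc(C2=NN(c3ccccc3)C(c3ccc(C)cc3)C2S(=O)(=O)CC2=NCCS2)cc1` gives 50.7%. Between these two, a group of 5 heavy atoms (3 carbon, 1 nitrogen, 1 oxygen; one five-membered non-aromatic ring with 2 hetero atoms) in place of a group of 5 heavy atoms (3 carbon, 1 nitrogen, 1 sulfur; one five-membered non-aromatic ring with 2 hetero atoms), on a saturated chain carbon bound to a sulfonyl sulfur raised the read-out by a number 19.8 percentage points higher from compound 3 to compound 2 (beyond the scatter). The difference between the core of compound 1 and the core of compound 3 is not broken down here. Compound 4 `O=S(=O)(CC1=NCCO1)C1C(c2ccccc2)=NN(c2ccccc2)C1c1ccccc1` carries the same change on the core of compound 1, namely (a group of 5 heavy atoms (3 carbon, 1 nitrogen, 1 oxygen; one five-membered non-aromatic ring with 2 hetero atoms) in place of a group of 5 heavy atoms (3 carbon, 1 nitrogen, 1 sulfur; one five-membered non-aromatic ring with 2 hetero atoms), on a saturated chain carbon bound to a sulfonyl sulfur). Since compound 1 has no number in this assay, only a starting point near inactivity can be assumed, and the step is expected to be of the same order as a number 19.8 percentage points higher from compound 3 to compound 2 (beyond the scatter), though a different core may not carry it over. Compound 4 is therefore estimated at 25% in this assay, with a range of 0% to 55%.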

Compound 4, a percentage reported as activity, at one concentration (the size of the read-out at that concentration, not a potency): 57.9%
Beside the measured number, compound 4's estimate is 32.9 percentage points below it; the measured number lies above the stated range.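

Among the compounds shown here, compound 1 carries no number in this assay, and no step to compound 4 can be read. The size of this group change on the core of compound 1 stays open, and no data shown explain the result.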